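A few compounds are considered here, and "the series" means these few. Any claim that something is new, unique, unknown or untested is made for them only; others in the source may bear on it.

Measured compounds:
compound 1, `O=C(NNC(=O)c1ccccc1Cl)c1ccc(NS(=O)(=O)c2cnc(O)nc2O)cc1`, 5220 nM
compound 2, `O=C(NNC(=O)c1cccc(Cl)c1)c1ccc(NS(=O)(=O)c2cnc(O)nc2O)cc1`, 7710 nM
compound 3, `O=C(NNC(=O)c1ccccc1Cl)c1cccc(NS(=O)(=O)c2cnc(O)nc2O)c1`, 7300 nM

In a functional assay on OVCAR-3 cells (Homo sapiens) for antiproliferative activity, read by MTT assay, with a stated time of 24 h (on this read-out lower numbers stand for stronger inhibition and higher numbers for weaker inhibition), compound 1 gives 5220 nM, compound 2 gives 7710 nM and compound 3 gives 7300 nM. Compound 2 differs from compound 1 by one change, (3-chlorophenyl in place of 2-chlorophenyl on a carbonyl carbon), and that change made a step of a 1.5-fold higher number from compound 1 to compound 2 (0.17 log units; within the scatter). The three values sit close together, and no one of them can be called stronger or weaker than another.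

Compound 4, `O=C(NNC(=O)c1cccc(NS(=O)(=O)c2cnc(O)nc2O)c1)c1cccc(Cl)c1`, has not yet been measured in this assay. It differs from compound 3 by 3-chlorophenyl in place of 2-chlorophenyl on a carbonyl carbon, the same change that turned compound 1 into compound 2, made at the same place. How the core of compound 3 differs from the core of compound 1 is not broken down here.

Because the earlier step of a 1.5-fold higher number from compound 1 to compound 2 (0.17 log units; within the scatter) was small, compound 4 is expected to move from compound 3 by a similarly small step, estimated as a 1.3-fold higher number from compound 3 to compound 4 (0.11 log units; within the scatter). On that basis compound 4 is estimated at 9500 nM, with a likely range from 5000 nM to 18000 nM.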

Compound 4, half-maximal inhibitory concentration: 13500 nM
The estimate for compound 4 lay 1.4-fold (0.15 log units) below the measured number; low and high end bracket the measured number.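

In this assay, 3-chlorophenyl in place of 2-chlorophenyl on a carbonyl carbon gives a 1.8-fold higher number from compound 3 to compound 4 (0.27 log units; within the scatter). Set beside the earlier step, the same change reads alike on the two cores, with no difference that can be told apart: the same change on two cores in this assay, a 1.5-fold higher number (0.17 log units; within the scatter) from compound 1 to compound 2 and a 1.8-fold higher number (0.27 log units; within the scatter) from compound 3 to compound 4, 1.3-fold (0.10 log units) apart, within the scatter of two such steps Both steps lie within the scatter and only two cores are shown, so the pair does not establish that the change has any effect of its own on either core, nor that it would read alike on a further core in this series.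

The compounds shown leave open how this assay would read with a plain phenyl, a methoxyphenyl or a pyridine ring on that carbonyl carbon, since both positions of chlorine shown here give values that stay close together. They also leave open whether an amine or a carboxylic acid on that aromatic ring would give a step beyond the scatter.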